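Tolerance in cultured cells across three related compounds

The source may report more compounds than this note shows. Statements on the series, on what has been measured and on what is new or still open speak of the compounds shown alone.

Compound 1, `COc1ccc(-c2nc(CSc3cccc(Cl)c3Cl)nc3ccsc23)cn1`: > 50000 nM
Compound 2, `COc1ccc(-c2nc(CS(=O)(=O)c3cccc(Cl)c3)nc3ccsc23)cn1`: > 10000 nM

This account concerns an ADME assay on cells (Homo sapiens) for cytotoxicity, read by resazurin assay, with a stated time of 5 days; a higher number here means that more compound is tolerated, a lower number that less compound is tolerated. In this assay compound 1 gives > 50000 nM, which is a limit of the assay and not a number. Compound 2 in this assay gives > 10000 nM, again a limit and not a number. Within the data shown here, compound 1 therefore stands only at the limit of > 50000 nM in this assay, at which 1 of the 2 values shown sits, and the one other value shown is itself a limit, (the limit of > 10000 nM in this assay, at which 1 of the 2 values shown sits); neither gives a measured number, so no step between measured compounds can be drawn from them.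

Compound 3, `COc1ccc(-c2nc(C[S+]([O-])c3cccc(Cl)c3)nc3ccsc23)cn1`, has not yet been measured in this assay. It differs from compound 1 by a group of 9 heavy atoms (6 carbon, 1 oxygen, 1 sulfur, 1 chlorine; one six-membered aromatic ring of carbon only) in place of a group of 9 heavy atoms (6 carbon, 1 sulfur, 2 chlorine; one six-membered aromatic ring of carbon only), on a saturated chain carbon bound to an aromatic carbon. Among the measured compounds shown here, no step between measured compounds is available to guide the expectation. With both known values sitting at limits, no change beyond the usual scatter is expected in this assay from this replacement, and compound 3 is expected most likely to return a limit once more. Compound 3 is estimated at 50000 nM, within a range from 15000 nM to 150000 nM. That estimate means an expected step of a number no higher from compound 1 to compound 3 (the limit leaves the size open).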

Compound 3, half-maximal cytotoxic concentration: > 50000 nM
Compound 3 was reported as a limit; the forecaster's own chance of this, stated with the estimate: 85%; the middle value sits exactly at the limit.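

In this assay, compound 1 and compound 3 both stop at a limit and not at a number, so no step can be read between them: the limit of > 50000 nM in this assay, at which 2 of the 3 values shown sit.

The compounds shown leave open at what concentration cells would stop tolerating any of them, and whether this replacement on the saturated chain carbon changes that tolerance at all.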